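The compounds below may be only part of what the source reports. "The series", "measured", "known", "first", "only" and "open" are said of these compounds alone.

Of the compounds shown here, two have been measured so far. Compound 1 `c1ccc(OC2CC2)c(OCC2=NCCN2)c1` carries a cyclopropyloxy group on its aromatic ring, and in an assay on isolated protein for binding affinity to Alpha-2C adrenergic receptor (Homo sapiens) (on this read-out lower numbers stand for stronger inhibition and higher numbers for weaker inhibition), compound 1 gives 794 nM. Compound 2 `CCCc1ccccc1OC(C)C1=NCCN1` is the other measured member, and in this assay compound 2 gives 148 nM. On these two numbers compound 1 stands at the higher end, and the gap between the two values lies beyond the usual scatter of the measurement.

The step under consideration leads from compound 1 to compound 3 `CCCc1ccccc1OCC1=NCCN1`, which has not yet been tested. The change is propyl in place of cyclopropyloxy on an aromatic carbon, so the oxygen and the three-membered ring are gone and a plain three-carbon chain takes their place on the same aromatic carbon, ortho to the group of seven heavy atoms that links the ring to the rest of the core. Within the data shown here, no directly comparable step between measured compounds exists here, so the expectation rests on the two values shown. Because compound 2 gives 148 nM in this assay, the change from compound 1 to compound 3 is expected to lower the number by a 4.0-fold lower number from compound 1 to compound 3 (0.60 log units; beyond the scatter). Compound 3 is therefore estimated at 200 nM, with a plausible range from 60 nM to 700 nM.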

Compound 3, inhibition constant: 490 nM
Compound 3: middle estimate off by 2.5-fold (0.39 log units), on the low side, within the range that was stated.
By their numbers in this assay, from the lowest: compound 2; then compounds 3 and 1 (each within the scatter of the next).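

In this assay, propyl in place of cyclopropyloxy on an aromatic carbon gives a 1.6-fold lower number from compound 1 to compound 3 (0.21 log units; within the scatter), so on this read-out the two groups cannot be told apart at this place on the ring, even though the oxygen and the three-membered ring are gone. The step beyond the scatter lies at a different place: hydrogen in place of methyl on a saturated chain carbon, bound to a carbon with a double bond to nitrogen and to an oxygen on an aromatic ring, gives a 3.3-fold higher number from compound 2 to compound 3 (0.52 log units; beyond the scatter), a modest step seen with propyl on the ring. No measurement shown here offers an explanation for either step.

On these data alone, it remains open whether a longer chain such as butyl, or an amine on the same aromatic carbon, would separate from propyl and cyclopropyloxy in this assay. It is also open whether the methyl on the saturated chain carbon would give a step of similar size with cyclopropyloxy on the ring, as the compounds shown offer that comparison only with propyl.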